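A Fluorine Enters Where Chlorine Made Little Difference

A few compounds are considered here, and "the series" means these few. Any claim that something is new, unique, unknown or untested is made for them only; others in the source may bear on it.

Compound 3 `Cn1c(=O)[nH]c2c(cnn2-c2ccccc2)c1=N` stands second highest of three compounds in an assay on membranes from brain for binding affinity to adenosine receptor A1 (Rattus norvegicus), read by radioligand binding, tested at 20 uM (a lower number here means less inhibition, a higher number more inhibition at the concentration tested (going by the name of the read-out)), where compound 3 gives 30%. Its nearest neighbour is compound 1 `Cn1c(=O)[nH]c2c(cnn2-c2ccc(Cl)cc2)c1=N`, which gives 37% in this assay; furthest away is compound 2 `Cn1c(=O)[nH]c2c(cnn2-c2ccc([N+](=O)[O-])cc2)c1=N`, which gives 5%. Compound 4 `Cn1c(=O)[nH]c2c(cnn2-c2ccc(F)cc2)c1=N` differs from compound 3 by fluoro in place of hydrogen on an aromatic carbon. Within the data shown here, two measured steps bear on this change. a number 7 percentage points lower from compound 1 to compound 3 (within the scatter) shows that swapping chloro for hydrogen on the aromatic carbon hardly moved the number, whereas a number 25 percentage points higher from compound 2 to compound 3 (beyond the scatter) shows that swapping nitro for hydrogen raised it. Fluoro, a halogen like chloro, makes the chloro step the closer guide, so the step is expected to be a number 3 percentage points higher from compound 3 to compound 4 (within the scatter), nothing beyond the scatter. Compound 4 is therefore estimated at 33%, with a range from 18% to 48%.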

Compound 4, a percentage reported as inhibition, at one concentration (the size of the read-out at that concentration, not a potency): 26%
Estimate against measurement, compound 4: 7 percentage points above; the range from low to high includes it.
By their numbers in this assay, from the lowest: compound 2; then compounds 4, 3 and 1 (each within the scatter of the next, the first and the last beyond it).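

Fluoro on this aromatic carbon, para to a large group, gives a number 4 percentage points lower from compound 3 to compound 4 (within the scatter) in this assay and so stays level with hydrogen. The two halogens can nonetheless be told apart, with a number 11 percentage points lower from compound 1 to compound 4 (beyond the scatter) when fluoro replaces chloro, a separation that compound 3 with its hydrogen did not show against compound 1. Fluoro also stays well clear of nitro, with a number 21 percentage points higher from compound 2 to compound 4 (beyond the scatter) in the same direction as the step from nitro to hydrogen.

As far as these compounds go, whether an amine or a carboxylic acid on this carbon would hold the number near these values stays open. Nothing available explains why fluoro and chloro part here.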